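Removing the Methyl from Compound 2: Expectation for Compound 4

This account rests on a few compounds, and the source may have more. Where it says the series, first, only, none or still open, it means among the compounds named here.

Compound 2 `COc1ccc(C(=O)/C=C/c2ccc(Cl)cc2)cc1`: 54 nM
Compound 3 `COc1ccc(C(=O)/C=C/c2ccc(OCc3ccccc3)cc2)cc1`: 450 nM
Compound 1 `CC(C)=CCOc1ccc(C(=O)/C=C/c2ccccc2)c(O)c1`: 18800 nM; 18600 nM (2 entries)

In an assay on isolated protein for inhibition of Amine oxidase [flavin-containing] B (Homo sapiens) (a higher number here means a weaker inhibitor, a lower number a stronger inhibitor), compound 2 gives 54 nM, the lowest of the two single numbers. Its nearest neighbour is compound 3, reached by an 8.3-fold higher number from compound 2 to compound 3 (0.92 log units; beyond the scatter), with benzyloxy in place of chloro. Compound 1 carries a free hydroxy group and gives 18800 nM; 18600 nM (2 entries), its two entries agreeing closely (the several entries of compound 1 in this assay, 18800 nM; 18600 nM (2 entries)), but it differs from compound 2 in several places at once.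

Compound 4 `O=C(/C=C/c1ccc(Cl)cc1)c1ccc(O)cc1` differs from compound 2 by hydrogen in place of methyl on an oxygen on an aromatic ring. No measured step touches this oxygen; the only step shown concerns another ring, so it gives no direct guide. A modest weakening in this assay is expected for compound 4, a 3.0-fold higher number from compound 2 to compound 4 (0.47 log units; beyond the scatter). Compound 4 is estimated at 160 nM, within 40 nM to 650 nM.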

Compound 4, half-maximal inhibitory concentration: 31 nM
Estimate against measurement, compound 4: 5.2-fold (0.71 log units) above; measured number below the stated range.
By their numbers in this assay, from the lowest: compounds 4 and 2 (each within the scatter of the next); then compound 3.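

In this assay, hydroxy in place of methoxy gives a 1.7-fold lower number from compound 2 to compound 4 (0.24 log units; within the scatter), so losing the methyl from this oxygen makes no readable difference. This is the first step shown at this position, and it shows that the methyl is not needed to keep the number in this range. Nothing measured here gives a reason for this outcome.

On these data alone, whether a longer chain on this oxygen, or an amine in place of the hydroxy, would keep that range remains open. So does whether the same change would behave alike with benzyloxy in place of chloro, as in compound 3.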